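Replacing a Vinyl Chain End with an Ethynyl One

The source may report more compounds than this note shows. Statements on the series, on what has been measured and on what is new or still open speak of the compounds shown alone.

Of the compounds shown here, three sharing one core have been tested in a functional assay on MCF7 cells (Homo sapiens) for cytotoxicity; a higher number here means that more compound is needed for the effect, a lower number that less compound is needed. Compound 1 `CCCCn1c(Cc2cc(OC)c(OC)c(OC)c2)nc2c(N)nc(F)nc21` gives 185000000 nM. Compound 2 `CCCCCCn1c(Cc2cc(OC)c(OC)c(OC)c2)nc2c(N)nc(F)nc21` gives 112000000 nM, and compound 3 `C=CCCn1c(Cc2cc(OC)c(OC)c(OC)c2)nc2c(N)nc(F)nc21` gives 102000000 nM. Compound 3 has the lowest of the three numbers, but its separation from compound 2 is a 1.1-fold lower number from compound 2 to compound 3 (0.04 log units; within the scatter) and from compound 1 is a 1.8-fold lower number from compound 1 to compound 3 (0.26 log units; within the scatter), so the three cannot be told apart with confidence. The step of a 1.7-fold lower number from compound 1 to compound 2 (0.22 log units; within the scatter) also falls within the scatter.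

Compound 4 `C#CCCn1c(Cc2cc(OC)c(OC)c(OC)c2)nc2c(N)nc(F)nc21` has not yet been measured. It differs from compound 3 by ethynyl in place of vinyl on a saturated chain carbon, two bonds along the chain from an aromatic nitrogen. The measured steps that bear on this position are a 1.8-fold lower number from compound 1 to compound 3 (0.26 log units; within the scatter) and a 1.1-fold lower number from compound 2 to compound 3 (0.04 log units; within the scatter), both within the scatter: exchanging ethyl or butyl for vinyl at the saturated chain carbon two bonds along the chain from an aromatic nitrogen did not move the readout in this assay beyond the usual spread. On that basis, the expected outcome is a step of a 1.0-fold lower number from compound 3 to compound 4 (0.01 log units; within the scatter) in this assay, meaning no change beyond the scatter. Compound 4 is therefore estimated at 100000000 nM, with a likely range from 40000000 nM to 250000000 nM.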

Compound 4, half-maximal effective concentration: 286000000 nM
Compound 4: middle estimate off by 2.9-fold (0.46 log units), on the low side; the whole stated range lies below it.
By their numbers in this assay, from the lowest: compounds 3, 2, 1 and 4 (each within the scatter of the next, the first and the last beyond it).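

For the compounds shown here, the triple bond at the chain end is the first change at this position to move the number beyond the scatter in this assay: ethynyl and vinyl have the same count of heavy atoms, yet the exchange gives a 2.8-fold higher number from compound 3 to compound 4 (0.45 log units; beyond the scatter). Compound 4 also stands apart from the longer saturated chain, with a 2.6-fold higher number from compound 2 to compound 4 (0.41 log units; beyond the scatter), but it cannot be told apart from the shorter saturated chain, where the comparison gives a 1.5-fold higher number from compound 1 to compound 4 (0.19 log units; within the scatter). The position is therefore not indifferent to every change at the chain end, although the clear steps are modest and the difference from compound 1 stays within the scatter, so the triple bond does not set compound 4 apart from all the others. Nothing available explains why ethynyl behaves differently from vinyl here.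

Going by these compounds, it remains open whether a longer chain ending in ethynyl would keep this step or lose it, and whether a nitrile, a hydroxyl or an amine at the chain end would move the number further. On these data alone, it is also open whether the same step would appear on cells other than this one line.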